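A few compounds are considered here, and "the series" means these few. Any claim that something is new, unique, unknown or untested is made for them only; others in the source may bear on it.

Measured in a functional assay on A-375 cells (Homo sapiens) for antiproliferative activity, read by CCK-8 assay, with a stated time of 72 h, tested at 2 uM; a lower number here means a weaker effect, a higher number a stronger effect of the compound at the concentration tested:
- compound 1 `Nc1ccccc1NC(=O)c1ccc(CSC(=S)N2CCN(c3ccc(Cl)cc3)CC2)cc1`: 32.2%
- compound 2 `CCN(Cc1ccncc1)C(=S)SCc1ccc(C(=O)Nc2ccccc2N)cc1`: 67.2%

Compound 1 gives the lower of the two inhibition values in this assay; compound 2 lies higher by a margin beyond the usual scatter. Compound 3 `Nc1ccccc1NC(=O)c1ccc(CSC(=S)N2CCN(c3ncccn3)CC2)cc1` has not been measured in this assay. It differs from compound 1 by one change: pyrimidin-2-yl in place of 4-chlorophenyl on an amine nitrogen in a ring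

Going by the values given here, no step between measured compounds shares this change, so nothing here tells its size or direction. The expected step of a number 2.2 percentage points lower from compound 1 to compound 3 (within the scatter) is small, not clearly beyond the scatter. Compound 3 is estimated at 30% in this assay, within 10% to 55%.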

Compound 3, a percentage reported as inhibition, at one concentration (the size of the read-out at that concentration, not a potency): 24%
Beside the measured number, compound 3's estimate is 6 percentage points above it; the measured number falls inside the stated range.
By their numbers in this assay, from the lowest: compounds 3 and 1 (each within the scatter of the next); then compound 2.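

In this assay, pyrimidin-2-yl in place of 4-chlorophenyl on an amine nitrogen in a ring gives a number 8.2 percentage points lower from compound 1 to compound 3 (within the scatter). At this position, then, a six-membered aromatic ring of carbon only and one with 2 hetero atoms cannot be told apart by this read-out. No measured data offer an explanation for this step.

Open, from the compounds shown here alone, is whether a non-aromatic group on this nitrogen, such as an ethyl group or a longer chain, would give a step beyond the scatter. The piperazine-free side of the series, compound 2, differs in more than one place and cannot be read against this change.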